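The source may report more compounds than this note shows. Statements on the series, on what has been measured and on what is new or still open speak of the compounds shown alone.

The account starts from compound 2 `COC(=O)/C(=C\c1ccc(OC(=O)c2cccc(OC)c2OC)cc1)Sc1ccnc2cc(Cl)ccc12`, which in a functional assay on Jurkat E6.1 cells (Homo sapiens) for cytotoxicity, read by MTT assay, with a stated time of 24 h (on this read-out higher numbers stand for weaker inhibition and lower numbers for stronger inhibition), gives 25800 nM. Going by the values given here, only one other compound has been measured in this assay: compound 1 `COC(=O)/C(=C\c1ccc(OC(=O)c2c(OC)cccc2OC)cc1)Sc1ccnc2cc(Cl)ccc12`, which gives 37500 nM. The two numbers lie within the scatter of each other, as the step of a 1.5-fold lower number from compound 1 to compound 2 (0.16 log units; within the scatter) shows, so neither compound can be set apart from the other on the numbers shown.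

The next compound, compound 3 `COC(=O)/C(=C\c1ccc(OC(=O)c2cc(OC)c(OC)cc2OC)cc1)Sc1ccnc2cc(Cl)ccc12`, differs from compound 2 in one place: 2,4,5-trimethoxyphenyl in place of 2,3-dimethoxyphenyl on a carbonyl carbon. Among the compounds with values here, the only measured step that bears on this change is the one from compound 1 to compound 2, in which the pattern of methoxy groups on the same phenyl ring was also rearranged, and that step stayed within the scatter. On this basis a change of methoxy count and pattern on that ring is expected to leave this assay largely unmoved, with no step beyond the scatter in either direction.

Compound 3 is therefore expected to give about 26000 nM, with a range from 9000 nM to 75000 nM. That expectation corresponds to a step of a 1.0-fold higher number from compound 2 to compound 3 (0.00 log units; within the scatter).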

Compound 3, half-maximal inhibitory concentration: 9650 nM
Estimate against measurement, compound 3: 2.7-fold (0.43 log units) above, and the stated range covers the measured number.
By their numbers in this assay, from the lowest: compound 3; then compounds 2 and 1 (each within the scatter of the next).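

The earlier step on this ring stayed within the scatter, but the phenyl group on this carbonyl carbon now proves able to shift the number in this assay: 2,4,5-trimethoxyphenyl in place of 2,3-dimethoxyphenyl gives a 2.7-fold lower number from compound 2 to compound 3 (0.43 log units; beyond the scatter), and in place of 2,6-dimethoxyphenyl it gives a 3.9-fold lower number from compound 1 to compound 3 (0.59 log units; beyond the scatter). Both steps are modest, yet they set compound 3 apart as the only one of the three whose number is separated from the others beyond the scatter, so this position is not indifferent to the substitution of the ring. No supporting evidence is available to account for this shift.

Since the count and the pattern of methoxy groups change together in both steps, the compounds shown leave open whether the lower number follows the additional methoxy group, its arrangement on the ring, or both. They also leave open how this assay would respond if a methoxy group on this ring gave way to a different group, such as an amine, a carboxylic acid or a longer chain like butoxy.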